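Ester chain extension on the coumarin-series benzyl ester

The source may report more compounds than this note shows. Statements on the series, on what has been measured and on what is new or still open speak of the compounds shown alone.

Compound 1 `CC(=O)OCc1ccc2oc(=O)c(C(=O)Oc3cccc(Br)c3)cc2c1` gives 39.5% in a functional assay on HT-1080 cells (Homo sapiens), read by transwell migration, with a stated time of 24 h, tested at 0.1 uM (on this read-out lower numbers stand for a stronger effect and higher numbers for a weaker effect at the one concentration tested), the lowest of the three numbers measured. Compound 2 `CC(=O)OCc1ccc2oc(=O)c(C(=O)Sc3cccc(Cl)c3)cc2c1` gives 76.5% and compound 3 `CC(=O)OCc1ccc2oc(=O)c(C(=O)Nc3cccc(Cl)c3)cc2c1` gives 79.6%; the steps of a number 37 percentage points higher from compound 1 to compound 2 (beyond the scatter) and a number 40.1 percentage points higher from compound 1 to compound 3 (beyond the scatter) are large, while a number 3.1 percentage points higher from compound 2 to compound 3 (within the scatter) is not.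

Compound 4 `CCCCCCC(=O)OCc1ccc2oc(=O)c(C(=O)Oc3cccc(Br)c3)cc2c1` differs from compound 1 by pentyl in place of hydrogen on a saturated chain carbon bound to a carbonyl carbon. Both measured steps from compound 1 alter the group on the other carbonyl carbon, so neither bears on this change; the acetyl end is untouched in every measured pair. No step beyond the scatter is therefore expected in this assay, only a number 2.5 percentage points higher from compound 1 to compound 4 (within the scatter). Compound 4 is estimated at 42%, within 22% to 65%.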

Compound 4, a percentage reported as activity, at one concentration (the size of the read-out at that concentration, not a potency): 89.4%
Compound 4: the middle estimate sits 47.4 percentage points below what was measured, and the stated range ends below it.
By their numbers in this assay, from the lowest: compound 1; then compounds 2, 3 and 4 (each within the scatter of the next, the first and the last beyond it).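

Among the compounds shown here, the acetyl end, untouched in the earlier pairs, is not a silent position: in this assay, pentyl in place of hydrogen on a saturated chain carbon bound to a carbonyl carbon gives a number 49.9 percentage points higher from compound 1 to compound 4 (beyond the scatter). For the compounds shown here, a change at this end alone therefore weakens the effect at the one concentration tested, so the earlier steps at the other carbonyl carbon did not cover all of the series' sensitivity. Nothing available bears on the cause of this step.

Only acetyl and hexylcarbonyl are shown at this place, which leaves open how an intermediate propanoyl or butanoyl chain would read. On these data alone, a chain ending in a carboxylic acid or an amine also remains open.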